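Aryl exchange on the five-membered ring: compound 2 to compound 3

The source may hold more compounds than are shown below. What is called first, only, known or untested is meant among the compounds shown, and "the series" means these compounds.

Compound 1 `CCCCCCCc1nncn1-c1ccc(OCCCCCC)cc1` carries a heptyl group on the five-membered aromatic ring with three nitrogen. In a functional assay on the whole organism (strain C57B/6) with Mus musculus as the target, in the maximal electroshock model (on this read-out higher numbers stand for an effect only at larger amounts of compound and lower numbers for an effect already at smaller amounts), compound 1 reaches only a limit, > 40 mg/kg. Compound 2 `CCCCCCOc1ccc(-n2cnnc2-c2cccc(F)c2)cc1` has a 3-fluorophenyl in that position and in this assay compound 2 gives 27.4 mg/kg. The step of an at least 1.4-fold lower number from compound 1 to compound 2 (0.16 log units; that floor lies within the scatter) is the only measured one in the series. Within the data shown here, compound 2 thus holds the only actual number among the two values shown; the other is the limit of > 40 mg/kg in this assay, at which 1 of the 2 values shown sits.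

Compound 3 `CCCCCCOc1ccc(-n2cnnc2-c2ccc(C)cc2)cc1` differs from compound 2 by 4-methylphenyl in place of 3-fluorophenyl on an aromatic carbon. The measured step from compound 1 to compound 2 traded an alkyl chain for an aromatic ring and reached only the floor of a limit, so it bears little on an exchange of one substituted phenyl for another. Among the measured compounds shown here, no measured step speaks to the size or direction of this change. In this assay compound 3 is therefore expected to lie close to compound 2, with a 1.0-fold lower number from compound 2 to compound 3 (0.01 log units; within the scatter) as a step not beyond the scatter. The estimate for compound 3 is 27 mg/kg, with a range from 12 mg/kg to 60 mg/kg.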

Compound 3, dose for half-maximal effect: 11.4 mg/kg
Compound 3: the middle estimate sits 2.4-fold (0.37 log units) above what was measured, and the stated range ends above it.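

In this assay, among these compounds, the aryl group on this aromatic carbon, between two ring nitrogen atoms, can be exchanged with a readable result: 4-methylphenyl in place of 3-fluorophenyl gives a 2.4-fold lower number from compound 2 to compound 3 (0.38 log units; beyond the scatter), the first step beyond the scatter. The exchange of the alkyl chain for an aryl group also becomes readable with this ring, as heptyl to 4-methylphenyl gives an at least 3.5-fold lower number from compound 1 to compound 3 (0.54 log units; beyond the scatter), whereas the floor of the step to compound 2 stayed within the scatter. Compound 1 remains a limit, so the true size of this step stays unknown: the limit of > 40 mg/kg in this assay, at which 1 of the 3 values shown sits.

The step from compound 2 to compound 3 changes both the substituent and its place on the phenyl ring, so the compounds shown do not separate the two; unsubstituted phenyl, 4-fluorophenyl and 3-methylphenyl would each divide that change. Also open, going by these compounds, is whether the lower number holds with a larger group at the same place on the ring, such as 4-ethylphenyl or 4-methoxyphenyl, or with a shorter chain on the ether oxygen of the shared core.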